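Swapping diisopropylamino for piperidin-1-yl: an untested analogue

The compounds below may be only part of what the source reports. "The series", "measured", "known", "first", "only" and "open" are said of these compounds alone.

Compound 1 `O=c1c(Cl)c(CSC(=S)N2CCCCC2)oc2ccccc12` and compound 2 `CC(C)N(C(=S)SCc1oc2ccccc2c(=O)c1Cl)C(C)C` share one core and differ only at the thiocarbonyl carbon. In a functional assay on HeLa cells (Homo sapiens) for antiproliferative activity, read by MTT assay, with a stated time of 72 h (a higher number here means a weaker inhibitor, a lower number a stronger inhibitor), compound 1 gives 9800 nM. For compound 2 this assay reports only a limit, > 40000 nM, and no number. The structural change between them is piperidin-1-yl in place of diisopropylamino on a thiocarbonyl carbon, and the resulting step is an at least 4.0-fold lower number from compound 2 to compound 1 (0.61 log units; beyond the scatter). Because compound 2 sits at the limit of > 40000 nM in this assay, at which 1 of the 3 values shown sits, the true size of this step is known only as a lower bound.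

Compound 3 `COc1ccc2oc(CSC(=S)N(C(C)C)C(C)C)cc(=O)c2c1` has a different core; the difference between the cores of compound 2 and compound 3 is not broken down here. For compound 3 this assay gives only a limit, > 25000 nM. Going by the values given here, compound 4 `COc1ccc2oc(CSC(=S)N3CCCCC3)cc(=O)c2c1` is compound 3 carrying the same change as the one from compound 2 to compound 1, namely (piperidin-1-yl in place of diisopropylamino on a thiocarbonyl carbon), at an identical place.

Since this change was measured only once, any expectation for compound 4 rests on that single pair together with the limit at the limit of > 25000 nM in this assay, at which 1 of the 3 values shown sits, for compound 3, which leaves the starting point uncertain. The step is expected to be an at least 2.0-fold lower number from compound 3 to compound 4 (0.31 log units; beyond the scatter), a little smaller than the measured one, because the starting value at the limit of > 25000 nM in this assay, at which 1 of the 3 values shown sits, is a limit, not a number. Compound 4 is therefore estimated at 12000 nM, with a likely range from 4000 nM to 40000 nM.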

Compound 4, half-maximal inhibitory concentration: 11900 nM
The estimate for compound 4 lay 1.0-fold (0.00 log units) above the measured number; low and high end bracket the measured number.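

In this assay, putting piperidin-1-yl in place of diisopropylamino on the core of compound 3 gives an at least 2.1-fold lower number from compound 3 to compound 4 (0.32 log units; beyond the scatter) and thus points the same way as the change on the core of compound 1. Compound 3 has only a limit of the assay, > 25000 nM and not a number, which means that this step, like the earlier one, is a lower bound on the real difference. The two cores therefore agree on the direction of the change, but this pair of results cannot show whether the change has the same size on both cores, and two cores alone do not establish a rule for the wider series: the same change on two cores in this assay, an at least 4.0-fold lower number (0.61 log units; beyond the scatter) from compound 2 to compound 1 and an at least 2.1-fold lower number (0.32 log units; beyond the scatter) from compound 3 to compound 4; the limit leaves it open whether they differ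

The compounds shown include only two groups on the thiocarbonyl carbon, diisopropylamino and piperidin-1-yl, so it remains open whether the lower number depends on having a ring there at all. A smaller ring such as pyrrolidin-1-yl, a ring with a second hetero atom such as morpholin-4-yl, or an open-chain group such as diethylamino could separate these possibilities, and none of them appears among these compounds.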